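The compounds below may be only part of what the source reports. "The series", "measured", "known", "first", "only" and "open" are said of these compounds alone.

Of the compounds shown here, three that share one core have been measured in a functional assay on HepG2 cells (Homo sapiens) for antiproliferative activity, read by spectrophotometry, with a stated time of 2 days (on this read-out higher numbers stand for weaker inhibition of growth and lower numbers for stronger inhibition of growth), and they differ only in the aryl group on a nitrogen on an aromatic ring. Compound 1 `Cc1cc(Cl)ccc1Nc1ncc(C(F)(F)F)c(N2Cc3cccc(N(C)S(C)(=O)=O)c3C2)n1` gives 19600 nM in this assay. Compound 2 `CN(c1cccc2c1CN(c1nc(Nc3ccc(Cl)c(C(F)(F)F)c3)ncc1C(F)(F)F)C2)S(C)(=O)=O` gives 16000 nM in this assay. Compound 3 `COc1cc(Nc2ncc(C(F)(F)F)c(N3Cc4cccc(N(C)S(C)(=O)=O)c4C3)n2)c(OC)cc1Cl` gives 25600 nM in this assay. Compound 3 has the highest of the three numbers, but its steps to the other two are within the scatter: a 1.3-fold higher number from compound 1 to compound 3 (0.12 log units; within the scatter) and a 1.6-fold higher number from compound 2 to compound 3 (0.20 log units; within the scatter), as is a 1.2-fold lower number from compound 1 to compound 2 (0.09 log units; within the scatter).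

Compound 4 `Cc1cc(C)cc(Nc2ncc(C(F)(F)F)c(N3Cc4cccc(N(C)S(C)(=O)=O)c4C3)n2)c1` has not yet been measured. Compared with compound 3 the change is 3,5-dimethylphenyl in place of 4-chloro-2,5-dimethoxyphenyl on a nitrogen on an aromatic ring. All three measured steps are changes of the same aryl group at the same place, and none of them moved the number beyond the scatter. On that basis the step from compound 3 to compound 4 is expected to be a 1.3-fold lower number from compound 3 to compound 4 (0.11 log units; within the scatter), that is, no change beyond the scatter in either direction. Compound 4 is therefore estimated to give about 20000 nM in this assay, with a range from 8000 nM to 50000 nM.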

Compound 4, concentration for 50% growth inhibition: > 30000 nM
Compound 4: only a limit was reported; the forecaster's own chance of this, stated with the estimate: 10%; at least 1.5-fold (0.17 log units) between middle value and limit.
By their numbers in this assay, from the lowest: compounds 2, 1 and 3 (each within the scatter of the next). At a limit, above all of these: compound 4.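

In this assay compound 4 is the only one of the series reported as a limit and not as a number: the limit of > 30000 nM in this assay, at which 1 of the 4 values shown sits. Read as floors, its steps are an at least 1.1-fold higher number from compound 3 to compound 4 (0.06 log units; that floor lies within the scatter), an at least 1.8-fold higher number from compound 2 to compound 4 (0.27 log units; that floor lies within the scatter) and an at least 1.5-fold higher number from compound 1 to compound 4 (0.18 log units; that floor lies within the scatter), so none of them can yet be said to go beyond the scatter, although the true steps may be larger. What is new is that the nitrogen on the aromatic ring now carries an aryl group made of carbon alone, without the chlorine found on the aryl groups of compound 1, compound 2 and compound 3, and this change gives no sign of stronger inhibition of growth than theirs.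

The compounds shown leave open how far the true value of compound 4 lies past its limit, and whether the missing chlorine, the missing methoxy groups or the placing of the two methyl groups matters most. They also leave open how this position would respond to an aryl group bearing an amine or a carboxylic acid, or to a longer chain in place of the aryl group.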